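The source may report more compounds than this note shows. Statements on the series, on what has been measured and on what is new or still open speak of the compounds shown alone.

Measured compounds in the series:

Compound 1 `Cc1cc(NC(=O)Cn2nnc(-c3ccccc3)n2)n(C2CCCCC2)n1`: in an assay on HEK293 cells for activation of Kir3.1/Kir3.2 (Homo sapiens), read by thallium flux (a higher number here means that more compound is needed for the effect, a lower number that less compound is needed), compound 1 gives 96 nM.
Compound 2 `Cc1cc(NC(=O)Cn2nnc(-c3ccccc3)n2)n(C2CCC(F)(F)CC2)n1`: in this assay compound 2 gives 84 nM.
Compound 3 `CCC(C)n1nc(C)cc1NC(=O)Cn1nnc(-c2ccccc2)n1`: in this assay compound 3 gives only a limit, > 5000 nM.

Compound 3 thus stands at the limit of > 5000 nM in this assay, at which 1 of the 3 values shown sits, without a number of its own. The two ring-bearing compounds sit close together, since a 1.1-fold lower number from compound 1 to compound 2 (0.06 log units; within the scatter). Against them the open-chain compound falls away: an at least 52-fold higher number from compound 1 to compound 3 (1.71 log units; beyond the scatter), and likewise an at least 59-fold higher number from compound 2 to compound 3 (1.77 log units; beyond the scatter). Both steps share the same change at the aromatic nitrogen, a ring replaced by sec-butyl.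

Compound 4 `Cc1cc(NC(=O)Cn2nnc(-c3ccccc3)n2)n(C2CCCC2)n1` reverses that kind of change: cyclopentyl in place of sec-butyl on an aromatic nitrogen. Among the measured compounds shown here, the steps that bear on it are the two large ones above, run backwards; cyclopentyl is a carbon ring like cyclohexyl, only one atom smaller, so a large step downward in this assay is expected, though not necessarily the full distance back to compound 1. Compound 4 is therefore estimated at 250 nM, with a range from 80 nM to 1500 nM. Measured against the limit, this estimate means an expected step of an at least 20-fold lower number from compound 3 to compound 4 (1.30 log units; beyond the scatter).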

Compound 4, half-maximal effective concentration: 163 nM
Beside the measured number, compound 4's estimate is 1.5-fold (0.19 log units) above it; low and high end bracket the measured number.
By their numbers in this assay, from the lowest: compounds 2, 1 and 4 (each within the scatter of the next). At a limit, above all of these: compound 3.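

In this assay, the loss seen with sec-butyl does not mean that only cyclohexyl rings work on this aromatic nitrogen: the smaller carbon ring, cyclopentyl, gives a large step back (an at least 30-fold lower number from compound 3 to compound 4 (1.48 log units; beyond the scatter)). Cyclopentyl also stays within the scatter of both six-membered rings (a 1.7-fold higher number from compound 1 to compound 4 (0.23 log units; within the scatter); a 1.9-fold higher number from compound 2 to compound 4 (0.29 log units; within the scatter)), so across these compounds the position accepts either ring size, with open-chain compound 3 the one exception. Going by these compounds, compound 3 has a limit rather than a number, so the full size of the step from it stays unknown: (the limit of > 5000 nM in this assay, at which 1 of the 4 values shown sits).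

On these data alone, whether the ring itself or the size of the group decides the outcome remains open; cyclobutyl and a longer open chain such as pentyl would help separate the two. As far as these compounds go, how a ring oxygen, as in tetrahydropyranyl, would fare at this position also remains open.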